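The source may report more compounds than this note shows. Statements on the series, on what has been measured and on what is new or still open speak of the compounds shown alone.

Measured so far, in a functional assay on B16-F10 cells (Homo sapiens) for cytotoxicity against B16-F10 (Mus musculus), read by MTT assay, with a stated time of 72 h; on this read-out lower numbers stand for an effect already at smaller amounts and higher numbers for an effect only at larger amounts of compound:
compound 1 `O=C1/C(=C\c2cccc(Br)c2)c2ccccc2N1c1c(Cl)cccc1Cl` gives 8 ug/mL;
compound 2 `CN(C)c1ccc(/C=C2\C(=O)N(c3c(Cl)cccc3Cl)c3ccccc32)cc1` reaches only a limit of the assay, > 100 ug/mL.

Compound 2 thus stands at the limit of > 100 ug/mL in this assay, at which 1 of the 2 values shown sits. Compound 3 `O=C1/C(=C\c2cccc(Cl)c2)c2ccccc2N1c1c(Cl)cccc1Cl` is not yet measured; it differs from compound 2 by 3-chlorophenyl in place of 4-(dimethylamino)phenyl on a double-bonded chain carbon bound to a double-bonded ring carbon. Among the compounds with values here, the only measured step that bears on this change runs the other way: an at least 12-fold higher number from compound 1 to compound 2 (1.09 log units; beyond the scatter). Reversing a closely related change, a large drop in this assay is expected, back toward compound 1. Compound 3 is therefore estimated to give about 10 ug/mL, between 4 ug/mL and 30 ug/mL. The expected step is an at least 10-fold lower number from compound 2 to compound 3 (1.00 log units; beyond the scatter).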

Compound 3, concentration for half-maximal effect: 8 ug/mL
Compound 3: middle estimate off by 1.3-fold (0.10 log units), on the high side; low and high end bracket the measured number.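

In this assay, chloro in place of bromo on the phenyl ring gives no change at the digits printed from compound 1 to compound 3 (within the scatter), so the two halogens cannot be told apart here. The large change at this position now appears with a second halogen-bearing phenyl, as an at least 12-fold lower number from compound 2 to compound 3 (1.09 log units; beyond the scatter). That step has no exact size, because compound 2 sits at a limit of the assay: the limit of > 100 ug/mL in this assay, at which 1 of the 3 values shown sits.

Still open, from the compounds shown here alone, is whether the loss in compound 2 comes from the dimethylamino group itself or from where it sits on the ring. How fluoro or a carboxylic acid would read at this position is open too.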